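Triazole aryl variation in the diaryl urea series

The compounds below may be only part of what the source reports. "The series", "measured", "known", "first", "only" and "open" are said of these compounds alone.

Among the measured compounds shown here, compound 1 `Cc1ccc(-n2cc(COc3cccc(NC(=O)Nc4ccc(Cl)c(C(F)(F)F)c4)c3)nn2)cc1` gives 5430 nM in a functional assay on HepG2 cells (Homo sapiens) for inhibition, read by MTT assay, with a stated time of 72 h (on this read-out higher numbers stand for weaker inhibition and lower numbers for stronger inhibition), the highest of the three numbers measured so far. Compound 2 `CC(C)c1ccccc1-n1cc(COc2cccc(NC(=O)Nc3ccc(Cl)c(C(F)(F)F)c3)c2)nn1` gives 1900 nM, and compound 3 `O=C(Nc1cccc(OCc2cn(-c3ccccc3F)nn2)c1)Nc1ccc(Cl)c(C(F)(F)F)c1` gives 1520 nM. Both changes at the aromatic nitrogen lowered the number: a 2.9-fold lower number from compound 1 to compound 2 (0.46 log units; beyond the scatter) and a 3.6-fold lower number from compound 1 to compound 3 (0.55 log units; beyond the scatter). Between the two, a 1.3-fold lower number from compound 2 to compound 3 (0.10 log units; within the scatter), so 2-isopropylphenyl and 2-fluorophenyl are not told apart on this read-out.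

Compound 4 `O=C(Nc1cccc(OCc2cn(-c3cccc(Br)c3)nn2)c1)Nc1ccc(Cl)c(C(F)(F)F)c1` starts again from compound 1 and changes the same aryl group: 3-bromophenyl in place of 4-methylphenyl on an aromatic nitrogen. The two measured steps that bear on this position are the ones from compound 1; both are modest and both run toward lower numbers, and both replace 4-methylphenyl with a ring carrying a group other than methyl. Whether 3-bromophenyl behaves like those groups is not shown by any measured pair, so only the direction is a guide. A modest step toward a lower number is therefore expected, of the size a 2.0-fold lower number from compound 1 to compound 4 (0.30 log units; within the scatter). For compound 4 the expected value in this assay is 2700 nM, with a range from 1200 nM to 6500 nM.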

Compound 4, half-maximal inhibitory concentration: 1040 nM
Compound 4: the middle estimate sits 2.6-fold (0.41 log units) above what was measured; measured number below the stated range.
By their numbers in this assay, from the lowest: compounds 4, 3 and 2 (each within the scatter of the next); then compound 1.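

A third replacement of the 4-methylphenyl on the aromatic nitrogen moves in the same direction in this assay (a 5.2-fold lower number from compound 1 to compound 4 (0.72 log units; beyond the scatter)), so the lower numbers are not confined to 2-isopropylphenyl and 2-fluorophenyl. The 3-bromophenyl of compound 4 is not separated from either of those groups (a 1.5-fold lower number from compound 3 to compound 4 (0.16 log units; within the scatter); a 1.8-fold lower number from compound 2 to compound 4 (0.26 log units; within the scatter)), which leaves compounds 2, 3 and 4 on one level with compound 1 alone apart. No measurement at hand accounts for this difference.

Open, on these data alone, is whether the number of compound 1 goes with the methyl group itself or with where it sits, a point that 3-methylphenyl and 4-bromophenyl would address. Also open, as far as these compounds go, is how an unsubstituted phenyl, or a ring carrying an amine or a carboxylic acid, would read at this position.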